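Removing the Trifluoromethyl Group from the Sulfonamide Ring

A few compounds are considered here, and "the series" means these few. Any claim that something is new, unique, unknown or untested is made for them only; others in the source may bear on it.

Two compounds share one core. Compound 1 `O=S(=O)(NCCCNc1nccc(-c2c(-c3cccc(F)c3)nc3sccn23)n1)c1ccc(Cl)cc1` gives 5900 nM in a functional assay on A-375 cells (Homo sapiens) for cytotoxicity, read by MTT assay; a lower number here means a stronger inhibitor, a higher number a weaker inhibitor. Compound 2 `O=S(=O)(NCCNc1nccc(-c2c(-c3cccc(F)c3)nc3sccn23)n1)c1ccc(C(F)(F)F)cc1` gives 7440 nM in this assay, the higher of the two numbers, though its gap to compound 1 lies within the usual scatter. Compound 3 `O=S(=O)(NCCNc1nccc(-c2c(-c3cccc(F)c3)nc3sccn23)n1)c1ccccc1` is not yet measured; it differs from compound 2 by hydrogen in place of trifluoromethyl on an aromatic carbon. Among the compounds with values here, no measured pair shows this change, so only a small step is expected in this assay, a 1.2-fold higher number from compound 2 to compound 3 (0.08 log units; within the scatter), likely not beyond the scatter. Compound 3 is therefore estimated at 9000 nM, between 3000 nM and 30000 nM.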

Compound 3, half-maximal inhibitory concentration: 11000 nM
For compound 3 the middle estimate is 1.2-fold (0.09 log units) below the measured one; low and high end bracket the measured number.
By their numbers in this assay, from the lowest: compounds 1, 2 and 3 (each within the scatter of the next).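

Hydrogen in place of trifluoromethyl on this aromatic carbon gives a 1.5-fold higher number from compound 2 to compound 3 (0.17 log units; within the scatter) in this assay, so the data do not separate the phenyl from the 4-(trifluoromethyl)phenyl. Putting (phenylsulfonyl)amino in place of (((4-chlorophenyl)sulfonyl)amino)methyl on the chain gives a 1.9-fold higher number from compound 1 to compound 3 (0.27 log units; within the scatter), so this larger change also stays inside the noise of the measurement. Nothing available explains these numbers. As far as these compounds go, whether an amine or a carboxylic acid on this ring carbon would move the number beyond the scatter remains open.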